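Acetylating the Amino Group of Compound 1

The source may report more compounds than this note shows. Statements on the series, on what has been measured and on what is new or still open speak of the compounds shown alone.

Compound 1 `Cc1ccc(N)cc1S(=O)(=O)N(C)/N=C/c1cnn2ccc(C#N)cc12` has no usable number to start from: in a functional assay on NZB5 cells (Homo sapiens) for inhibition, read by thymidine incorporation, with a stated time of 5 days (a lower number here means a stronger inhibitor, a higher number a weaker inhibitor), compound 1 is recorded as "not determined" (no result reported). Only two close relatives offer any guidance. Compound 2 `Cc1ccc([N+](=O)[O-])cc1C(=O)N(C)/N=C/c1cnn2ccc(C#N)cc12` gives > 20000 nM, which is a limit of the assay and not a number. For the measured compounds named here, compound 3 `Cc1ccc([N+](=O)[O-])cc1CN(C)/N=C/c1cnn2ccc(C#N)cc12` gives 1700 nM, the only true measurement in the set.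

Still unmeasured is compound 4 `CC(=O)Nc1ccc(C)c(S(=O)(=O)N(C)/N=C/c2cnn3ccc(C#N)cc23)c1`. The structural step is acetyl in place of hydrogen on a nitrogen on an aromatic ring, or amino to acetamido. Going by the values given here, no measured step shows what this change does, and compound 1 offers no baseline, so any forecast is loose. A moderate step towards weaker inhibition, meaning a higher number in this assay, is expected, with a wide margin in either direction. Among the compounds with values here, the forecast is anchored on compound 3 at 1700 nM, the one measured value available. For compound 4 the estimated value is 2500 nM, with an expected range from 400 nM to 15000 nM.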

Compound 4, half-maximal inhibitory concentration: > 20000 nM
Compound 4 ended at the assay's limit; the forecaster's own chance of this, stated with the estimate: 20%; middle value at least 8.0-fold (0.90 log units) from the limit.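

In this assay compound 4 gives > 20000 nM, which is a limit of the assay and not a number. For the compounds shown here, no step between compound 1 and compound 4 can be read from this. Going by these compounds, how far acetyl in place of hydrogen on this nitrogen shifts inhibition remains open.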